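A few compounds are considered here, and "the series" means these few. Any claim that something is new, unique, unknown or untested is made for them only; others in the source may bear on it.

Measured compounds:
Compound 1, `CN(C)C(=O)CN1CCC(c2cc3c(-c4ccc(=O)n(C5CCC5)c4)ccnc3[nH]2)CC1`: 1.9
Compound 2, `COc1cc(C(=O)N2CCCC2)ccc1-c1ccnc2[nH]c(C3CCOCC3)cc12`: 3
Compound 3, `CN(C)C(=O)CN1CCC(c2cc3c(-c4ccc(=O)n(C)c4)ccnc3[nH]2)CC1`: 1.1

In a physicochemical assay for lipophilicity, using the shake flask method, measured as octanol-water partition, at pH 7.4 (a lower number here means a more polar compound, a higher number a more lipophilic compound), compound 2 gives the highest of the three numbers. Compound 1 sits closest to it, and compound 3 furthest away; both gaps are beyond the scatter. Going by the values given here, the only step between measured compounds that differ in one place is the one with methyl in place of cyclobutyl on an aromatic nitrogen, a number 0.80 log units lower from compound 1 to compound 3 (beyond the scatter), and it says nothing direct about the change studied here.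

Compound 4 is `COc1cc(F)ccc1-c1ccnc2[nH]c(C3CCOCC3)cc12`. It differs from compound 2 in this way: fluoro in place of (pyrrolidin-1-yl)carbonyl on an aromatic carbon. Seven heavy atoms, including the one hydrogen-bond acceptor of that group, leave, and a single fluorine atom enters. Among the compounds with values here, no measured pair covers a change of this kind, so the expectation rests on the counted difference alone rather than on any step already seen in this assay. Removing a group that carries a hydrogen-bond acceptor and replacing it by fluoro is expected to push the number upward, by a modest margin. For compound 4 the expected step is a number 0.80 log units higher from compound 2 to compound 4 (beyond the scatter). The estimate for compound 4 in this assay is therefore 3.8, with a range from 3.3 to 4.3.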

Compound 4, distribution coefficient: 3.9
The estimate for compound 4 lay 0.10 log units below the measured number, and the stated range covers the measured number.
By their numbers in this assay, from the lowest: compound 3; then compound 1; then compound 2; then compound 4.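

In this assay, going by these compounds alone, the earlier compounds offered only one step, on an aromatic nitrogen, so they gave no reading for the aromatic carbon that is meta to the methoxy group. Compound 4 supplies that reading: fluoro in place of (pyrrolidin-1-yl)carbonyl gives a number 0.90 log units higher from compound 2 to compound 4 (beyond the scatter) and shows that the number responds to what sits at this carbon. However, the five-membered ring, the carbonyl and the hydrogen-bond acceptor all leave in this single change, and no measurement at hand accounts for the size of the step or divides it among those parts.

Still open, from the compounds shown here alone, is how the number would move at this same carbon with a nitrile, a carboxylic acid or a primary amine, any of which would help show whether the step follows the whole departing group or just one part of it. Within the data shown here, it is also open whether the same exchange would give a similar step in compounds without the methoxy group, since only one pair at this place can be read.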